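Replacing 4-cyanophenyl with 3-fluoro-4-methoxyphenyl at the assay limit

The source may report more compounds than this note shows. Statements on the series, on what has been measured and on what is new or still open speak of the compounds shown alone.

In an ADME assay on microsomes from liver (Mus musculus) for metabolic stability, read by LC-MS, with NADPH named in the record, with a stated time of 60 min, tested at 1 uM, in the absence of a further agent (a lower number here means that less of the compound is left, a higher number that more of the compound is left), compound 3 `CC(=O)N[C@@H]1CCN(c2cc(C)nn3c(-c4ccc(C#N)cc4)c(C)nc23)C1` gives > 95%, which is a limit and not a number. Compound 1 `COc1ccc(-c2c(C)nc3c(N4CC[C@@H](NC(C)=O)C4)cc(C)nn23)cc1OC` gives > 95%, also a limit. Compound 2 `CC(=O)N[C@@H]1CCN(c2cc(C)nn3c(-c4ccccc4)c(C)nc23)C1` gives > 95%, again a limit.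

Compound 4 `COc1ccc(-c2c(C)nc3c(N4CC[C@@H](NC(C)=O)C4)cc(C)nn23)cc1F` has 3-fluoro-4-methoxyphenyl in place of the 4-cyanophenyl of compound 3: 3-fluoro-4-methoxyphenyl in place of 4-cyanophenyl on an aromatic carbon.

Three measured steps change this same group: a step that the two limits leave unreadable from compound 1 to compound 3, a step that the two limits leave unreadable from compound 1 to compound 2 and a step that the two limits leave unreadable from compound 2 to compound 3. None gives a size because of the limit of > 95% in this assay, at which 3 of the 3 values shown sit. Still, no swap among these groups has brought a compound off the limit in this assay. The expected a number no higher from compound 3 to compound 4 (the limit leaves the size open) therefore has no clear direction and stays within the usual scatter. The estimate for compound 4 is 95%, with an expected range from 82% to 100%.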

Compound 4, percent of the compound remaining: > 95%
Compound 4: only a limit was reported; the forecaster's own chance of this, stated with the estimate: 65%; the middle value sits exactly at the limit.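

In this assay compound 4 gives > 95%, a limit and not a number. Within the data shown here, no step from compound 1, compound 2 or compound 3 to compound 4 can be read. How much of each compound is truly left stays open, because all four sit at the same limit: the limit of > 95% in this assay, at which 4 of the 4 values shown sit.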